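Methoxy for Methyl on the Thiourea Aryl Ring

A few compounds are considered here, and "the series" means these few. Any claim that something is new, unique, unknown or untested is made for them only; others in the source may bear on it.

Compound 2 `Cc1ccccc1NC(=S)N1CCc2c(sc(NC(=O)c3ccccc3C(F)(F)F)c2C(N)=O)C1` gives 47400 nM in a functional assay on MKN-74 cells (Homo sapiens) for antiproliferative activity, with a stated time of 24 h (a lower number here means a stronger inhibitor, a higher number a weaker inhibitor), the higher of the two numbers measured; compound 1 `NC(=O)c1c(NC(=O)c2ccccc2C(F)(F)F)sc2c1CCN(C(=S)Nc1ccccc1F)C2` gives 19600 nM. Among the compounds with values here, the only step so far, a 2.4-fold higher number from compound 1 to compound 2 (0.38 log units; beyond the scatter), shows that swapping the group on this aromatic carbon moves the number beyond the scatter. Compound 3 `COc1ccccc1NC(=S)N1CCc2c(sc(NC(=O)c3ccccc3C(F)(F)F)c2C(N)=O)C1` carries methoxy in place of methyl on an aromatic carbon. Within the data shown here, no measured step covers methyl against methoxy here, so an expected step of a 1.1-fold lower number from compound 2 to compound 3 (0.02 log units; within the scatter) within the scatter is the most that can be said. Compound 3 is therefore estimated at 45000 nM, with a range of 18000 nM to 110000 nM.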

Compound 3, half-maximal inhibitory concentration: 34500 nM
Estimate against measurement, compound 3: 1.3-fold (0.12 log units) above, within the range that was stated.
By their numbers in this assay, from the lowest: compounds 1, 3 and 2 (each within the scatter of the next, the first and the last beyond it).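

In this assay, placing methoxy on this aromatic carbon gives a 1.4-fold lower number from compound 2 to compound 3 (0.14 log units; within the scatter), and the comparison with fluoro gives a 1.8-fold higher number from compound 1 to compound 3 (0.25 log units; within the scatter), so compound 3 cannot be separated from either compound 2 or compound 1, although those two lie beyond the scatter of each other. The entering oxygen, with its hydrogen-bond acceptor, therefore brings no step beyond the scatter here. No evidence is available to explain these readings.

As far as these compounds go, whether an amine, a carboxylic acid or a longer chain such as ethoxy on this aromatic carbon would move the number beyond the scatter remains open.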